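A few compounds are considered here, and "the series" means these few. Any claim that something is new, unique, unknown or untested is made for them only; others in the source may bear on it.

Three compounds built on one shared core were measured in a functional assay on PANC-1 cells (Homo sapiens) for inhibition, read by MTT assay, with a stated time of 24 h, tested at 10 uM; on this read-out lower numbers stand for less inhibition and higher numbers for more inhibition at the one concentration tested (going by the name of the read-out). Compound 1 `CC(C)=CCC1Cc2c(OCc3ccccc3)cc(=O)n(CCCO)c2CC1(C)C` gives 11.1% in this assay. Compound 2 `COc1cccc(NC(=O)Oc2cc(=O)n(CCCO)c3c2CC(CC=C(C)C)C(C)(C)C3)c1` gives 0%, and the step of a number 11.1 percentage points lower from compound 1 to compound 2 (beyond the scatter) went with (3-methoxyphenyl)carbamoyl in place of benzyl on an oxygen on an aromatic ring. Compound 3 `COc1cccc(NC(=O)Oc2cc(=O)n(CCCO)c3c2CC(C/C=C(\C)CCC=C(C)C)C(C)(C)C3)c1` gives 11.3%, the step of a number 11.3 percentage points higher from compound 2 to compound 3 (beyond the scatter) going with 3-methylbut-2-en-1-yl in place of hydrogen on a saturated chain carbon bound to a double-bonded chain carbon. Among the three numbers, compound 3 is level with compound 1 within the scatter and lies beyond the scatter above compound 2.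

Compound 4 `CC(C)=CCC/C(C)=C/CC1Cc2c(OC(=O)Nc3ccc(Cl)c(Cl)c3)cc(=O)n(CCCO)c2CC1(C)C` differs from compound 3 only at the amide-type nitrogen of the carbamoyl group: 3,4-dichlorophenyl in place of 3-methoxyphenyl on an amide-type nitrogen. Neither measured step touches this position; both were modest and concern other parts of the molecule, so nothing measured speaks directly to this change. A step of a number 0.7 percentage points higher from compound 3 to compound 4 (within the scatter) is therefore expected for compound 4, which amounts to none beyond the scatter. Compound 4 is estimated at 12%, with a range from 0% to 30%.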

Compound 4, a percentage reported as inhibition, at one concentration (the size of the read-out at that concentration, not a potency): 0%
For compound 4 the middle estimate is 12 percentage points above the measured one, within the range that was stated.
By their numbers in this assay, from the lowest: compounds 2 and 4 (each within the scatter of the next); then compounds 1 and 3 (each within the scatter of the next).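

In this assay the swap of 3-methoxyphenyl for 3,4-dichlorophenyl on the amide-type nitrogen goes with a number 11.3 percentage points lower from compound 3 to compound 4 (beyond the scatter) and is the first change shown at this position. The group on this nitrogen is therefore not a silent part of the molecule in this assay, even though the step is modest and all the numbers are small. No measured evidence on the cause of this step is at hand.

A single pair cannot show whether the step goes with losing the methoxy group or gaining the two chlorines, and a plain phenyl or a 3-chlorophenyl on the same nitrogen would help separate these. Going by these compounds, whether a non-aromatic group there, such as cyclohexyl, would keep or lose the read-out also remains open.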